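Pyridyl for Fluorophenyl in a Series at the Solubility Floor

This account rests on a few compounds, and the source may have more. Where it says the series, first, only, none or still open, it means among the compounds named here.

Compound 1 `CCCOc1ccc(C[C@@H](Cc2ccccc2)C(=O)O)cc1CNC(=O)c1ccc(-c2cccc(F)c2)cc1`: in a physicochemical assay for solubility, read by HPLC, in phosphate buffer, measured as thermodynamic solubility, with a stated time of 48 h, at pH 7.2 (a higher number here means a more soluble compound, a lower number a less soluble compound), compound 1 gives < 1 ug/mL, a limit of the assay rather than a number.
Compound 2 `CCCOc1ccc(C[C@@H](Cc2ccccc2)C(=O)O)cc1CNC(=O)c1ccc(-c2ccc(F)cc2)cc1`: in this assay compound 2 gives < 1 ug/mL, also a limit.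
Compound 3 `CCCOc1ccc(C[C@@H](Cc2ccccc2)C(=O)O)cc1CNC(=O)c1ccc(-c2ccccc2F)cc1`: in this assay compound 3 gives < 1 ug/mL, again a limit.

Within the data shown here, compound 3 therefore stands at the floor shared by every value so far (the limit of < 1 ug/mL in this assay, at which 3 of the 3 values shown sit). The three measured steps, a step that the two limits leave unreadable from compound 1 to compound 2, a step that the two limits leave unreadable from compound 1 to compound 3 and a step that the two limits leave unreadable from compound 2 to compound 3, carry no readable size, so moving the fluorine around the outer ring tells nothing about direction. Compound 4 `CCCOc1ccc(C[C@@H](Cc2ccccc2)C(=O)O)cc1CNC(=O)c1ccc(-c2ccccn2)cc1` brings a different kind of change: pyridin-2-yl in place of 2-fluorophenyl on an aromatic carbon. Among the measured compounds shown here, no measured step covers this swap, so the expectation rests on the counted difference alone. Compound 4 is expected to give 1.5 ug/mL, within 0.5 ug/mL to 6 ug/mL, and the expected step is an at least 1.5-fold higher number from compound 3 to compound 4 (0.17 log units; that floor lies within the scatter).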

Compound 4, solubility: 17 ug/mL
Compound 4: the middle estimate sits 11-fold (1.05 log units) below what was measured, and the stated range ends below it.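

At this position, the kind of ring matters in a way that moving the fluorine did not show: pyridin-2-yl in place of a fluorophenyl ring gives, in this assay, an at least 17-fold higher number from compound 3 to compound 4 (1.23 log units; beyond the scatter) and likewise an at least 17-fold higher number from compound 2 to compound 4 (1.23 log units; beyond the scatter) and an at least 17-fold higher number from compound 1 to compound 4 (1.23 log units; beyond the scatter). The steps among the three fluorophenyl compounds cannot be read, so any differences among them stay hidden: the limit of < 1 ug/mL in this assay, at which 3 of the 4 values shown sit.

Still open, on these data alone, is whether a plain phenyl ring here would stand with the fluorophenyl compounds or nearer compound 4. As far as these compounds go, how pyridin-3-yl or pyridin-4-yl would compare also remains open.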